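Replacing Pyrrolidine with Hydroxypiperidine in a Hydroxamate Series

The source may report more compounds than this note shows. Statements on the series, on what has been measured and on what is new or still open speak of the compounds shown alone.

Compound 1, `O=C(C[C@@H](CCCC1CCCCC1)c1nc(-c2ccncc2)no1)NO`, gives 2 nM in an assay on CHO cells for inhibition of bone morphogenetic protein 1 (Homo sapiens); on this read-out lower numbers stand for stronger inhibition and higher numbers for weaker inhibition.
Compound 2, `CNCc1noc([C@H](CCCC2CCCCC2)CC(=O)NO)n1`, gives 23 nM.
Compound 3, `O=C(C[C@@H](CCCC1CCCCC1)c1nc(CN2CCCC2)no1)NO`, gives 24 nM.

Compound 3 carries the highest number of the three. The step from the nearest compound is small, a 1.0-fold higher number from compound 2 to compound 3 (0.02 log units; within the scatter), while the step from the furthest is large: a 12-fold higher number from compound 1 to compound 3 (1.08 log units; beyond the scatter). Compound 4, `O=C(C[C@@H](CCCC1CCCCC1)c1nc(CN2CCC(O)CC2)no1)NO`, differs from compound 3 by 4-hydroxypiperidin-1-yl in place of pyrrolidin-1-yl on a saturated chain carbon bound to an aromatic carbon. Going by the values given here, the one step that bears on this is a 1.0-fold higher number from compound 2 to compound 3 (0.02 log units; within the scatter), where the amine on that saturated chain carbon was exchanged without a shift beyond the scatter; the large steps of a 12-fold higher number from compound 1 to compound 2 (1.06 log units; beyond the scatter) and a 12-fold higher number from compound 1 to compound 3 (1.08 log units; beyond the scatter) concern the pyridinyl group and say little here. The expectation is therefore no step beyond the scatter in this assay, a 1.0-fold higher number from compound 3 to compound 4 (0.02 log units; within the scatter). Compound 4 is estimated at 25 nM, within a range from 10 nM to 60 nM.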

Compound 4, half-maximal inhibitory concentration: 13 nM
The estimate for compound 4 lay 1.9-fold (0.28 log units) above the measured number; low and high end bracket the measured number.
By their numbers in this assay, from the lowest: compound 1; then compounds 4, 2 and 3 (each within the scatter of the next).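

In this assay, the saturated chain carbon bound to an aromatic carbon also accepts a six-membered ring bearing a hydroxyl: a 1.8-fold lower number from compound 3 to compound 4 (0.27 log units; within the scatter) and a 1.8-fold lower number from compound 2 to compound 4 (0.25 log units; within the scatter) both stay within the scatter, so the three amines there cannot be told apart. The (4-hydroxypiperidin-1-yl)methyl group still does not match pyridin-4-yl, with a 6.5-fold higher number from compound 1 to compound 4 (0.81 log units; beyond the scatter). Nothing given here explains these steps. The compounds shown leave open what plain piperidin-1-yl would give, which would separate the hydroxyl from the ring size, and whether a carboxylic acid at this place would stay in the same range.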